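This account rests on a few compounds, and the source may have more. Where it says the series, first, only, none or still open, it means among the compounds named here.

In a functional assay on HepG2 cells (Homo sapiens) for cytotoxicity, read by MTT assay, with a stated time of 24 h (a lower number here means a stronger inhibitor, a higher number a weaker inhibitor), three compounds have been measured so far:
- compound 1 (`COc1ccc(/C=C2\CN(C)C/C(=C\c3ccccc3F)C2=O)cc1`) gives 12300 nM
- compound 2 (`COc1cc(/C=C2\CN(C)C/C(=C\c3ccc(Cl)cc3)C2=O)cc(OC)c1`) gives 5950 nM
- compound 3 (`COc1cc(/C=C2\CN(C)C/C(=C\c3cc(OC)c(OC)c(OC)c3)C2=O)cc(OC)c1`) gives 890 nM

Compound 3 stands lowest of the three numbers, and both compound 2 and compound 1 lie beyond the scatter from it. Compound 4 (`COc1cc(/C=C2\CN(C)C/C(=C\c3ccc(Cl)cc3)C2=O)cc(OC)c1OC`) has not yet been measured. Compared with compound 3, it carries 4-chlorophenyl in place of 3,5-dimethoxyphenyl on a double-bonded chain carbon bound to a double-bonded ring carbon. For the measured compounds named here, no two measured compounds differ in one place only, so the change has no direct precedent here. Compound 2, which also carries 4-chlorophenyl, gives 5950 nM and sits higher than compound 3, which lacks that group and gives 890 nM. On that limited evidence, a rise beyond the scatter in this assay is expected, making this a weaker inhibitor. The estimated change is a 3.4-fold higher number from compound 3 to compound 4 (0.53 log units; beyond the scatter) as a moderate expected step. For compound 4 the estimated value is 3000 nM with an expected range from 1000 nM to 8000 nM in this measurement.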

Compound 4, half-maximal inhibitory concentration: 8250 nM
Compound 4: the middle estimate sits 2.8-fold (0.44 log units) below what was measured, and the stated range ends below it.
By their numbers in this assay, from the lowest: compound 3; then compounds 2, 4 and 1 (each within the scatter of the next, the first and the last beyond it).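

In this assay, for the compounds shown here, the first direct comparison at this place shows that 4-chlorophenyl in place of 3,5-dimethoxyphenyl on a double-bonded chain carbon bound to a double-bonded ring carbon gives a 9.3-fold higher number from compound 3 to compound 4 (0.97 log units; beyond the scatter) as a step beyond the scatter. The second pair, methoxy in place of hydrogen on an aromatic carbon, gives a 1.4-fold higher number from compound 2 to compound 4 (0.14 log units; within the scatter) and stays within the scatter, so that exchange shows no clear effect in these compounds. No measured evidence here explains either step.

A single pair cannot separate the arrival of the chlorine from the departure of the two methoxy groups. On these data alone, how an amine or a hydroxyl in place of that chlorine would read in this assay remains open, as does whether the step holds on a different partner group elsewhere on the shared core.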